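From 3-fluorophenyl to 2-hydroxyphenyl on a shared core

The source may hold more compounds than are shown below. What is called first, only, known or untested is meant among the compounds shown, and "the series" means these compounds.

- compound 1 `NC1CCC(Nc2nc(NCc3ccc(-n4cccn4)cc3)c3ncn(C4CCCC4)c3n2)CC1`: 139 nM
- compound 2 `NC1CCC(Nc2nc(NCc3ccc(-c4cccc(F)c4)nc3)c3ncn(C4CCCC4)c3n2)CC1`: 33 nM

In a functional assay on MCF7 cells (Homo sapiens) for inhibition, with a stated time of 72 h (on this read-out higher numbers stand for weaker inhibition and lower numbers for stronger inhibition), compound 2 gives 33 nM, the lower of the two numbers. Compound 1 stands higher at 139 nM, and this gap lies beyond the scatter. The two compounds differ in more than one place, so their values say little about any single group.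

The next compound is compound 3 `NC1CCC(Nc2nc(NCc3ccc(-c4ccccc4O)nc3)c3ncn(C4CCCC4)c3n2)CC1`, which keeps the rest of compound 2 unchanged. It carries 2-hydroxyphenyl in place of 3-fluorophenyl on an aromatic carbon of a six-membered aromatic ring with 1 nitrogen, next to the ring nitrogen and para to a large group (2-hydroxyphenyl in place of 3-fluorophenyl on an aromatic carbon). The group that leaves and the group that enters are each one six-membered aromatic ring of carbon only. Among the measured compounds shown here, no measured step shows what such a swap does here, so the expectation starts from compound 2 at 33 nM.

A slight rise in the number, not beyond the scatter, is expected in this assay, and the estimated change is a 1.4-fold higher number from compound 2 to compound 3 (0.13 log units; within the scatter). The estimated value for compound 3 is 45 nM, with an expected range of 15 nM to 130 nM.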

Compound 3, half-maximal inhibitory concentration: 18 nM
Compound 3: the middle estimate sits 2.5-fold (0.40 log units) above what was measured; low and high end bracket the measured number.
By their numbers in this assay, from the lowest: compounds 3 and 2 (each within the scatter of the next); then compound 1.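

In this assay, among the compounds shown here, replacing 3-fluorophenyl with 2-hydroxyphenyl on the six-membered aromatic ring with 1 nitrogen gives a 1.8-fold lower number from compound 2 to compound 3 (0.26 log units; within the scatter), the first single-place comparison in this set. The entering group carries 1 hydrogen-bond donor and 1 hydrogen-bond acceptor where the leaving group carries neither, yet the two compounds remain within the scatter of each other, so this one pair shows that the position accepts the swap without a readable change in this assay. Nothing available explains this outcome or ties it to either group.

The swap changes both the atom on the ring and its place on that ring, so this pair cannot separate the two changes; 3-hydroxyphenyl or 2-fluorophenyl at this position would be needed to tell them apart. From the compounds shown here alone, it also remains open whether this position would accept unsubstituted phenyl, a phenyl ring bearing an amine or a carboxylic acid, or the pyrazole-bearing arrangement of compound 1, which differs from compound 2 in more than one place.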